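The source may report more compounds than this note shows. Statements on the series, on what has been measured and on what is new or still open speak of the compounds shown alone.

Working notes on the hydrazone series. Compound 1 `COc1cc2c(Oc3ccc(NC(=O)N/N=C/c4ccc(Cl)cc4Cl)cc3F)ccnc2cc1OCCCN1CCCCC1` has no result in a functional assay on A549 cells (Homo sapiens) for cytotoxicity, read by MTT assay, with a stated time of 72 h; on this read-out higher numbers stand for weaker inhibition and lower numbers for stronger inhibition; its entry reads "not determined" (no result reported). Going by the values given here, compound 2 `COc1cc2c(Oc3ccc(NC(=O)N/N=C/c4ccc(O)cc4)cc3F)ccnc2cc1OCCCN1CCCCC1` is the one member with a number: in this assay compound 2 gives 780 nM. Among the compounds with values here, that value stands alone; with compound 1 carrying no number, compound 2 can be set against nothing else, and no step between two measured compounds exists.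

Compound 3 `COc1cc2c(Oc3ccc(NC(=O)N/N=C/c4cc5ccccc5[nH]4)cc3F)ccnc2cc1OCCCN1CCCCC1` remains to be measured in this assay. It differs from compound 2 in one place: 1H-indol-2-yl in place of 4-hydroxyphenyl on a carbon with a double bond to nitrogen. The rest of the molecule is untouched.

Within the data shown here, with no comparable step to draw on, the expectation rests on the single value of compound 2 and on the size of the swap. The step from compound 2 to compound 3 is expected to be a 1.3-fold lower number from compound 2 to compound 3 (0.11 log units; within the scatter), which is read as no change beyond the usual scatter, with only a slight lean toward stronger inhibition. For compound 3 the expected value in this assay is 600 nM, with a range from 150 nM to 2500 nM.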

Compound 3, half-maximal inhibitory concentration: 780 nM
Estimate against measurement, compound 3: 1.3-fold (0.11 log units) below; the measured number falls inside the stated range.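

Going by these compounds alone, this is the first readable step: in this assay, 1H-indol-2-yl in place of 4-hydroxyphenyl on a carbon with a double bond to nitrogen gives no change at the digits printed from compound 2 to compound 3 (within the scatter). At this position, then, a single six-membered aromatic ring carrying a hydroxyl can be exchanged for a fused pair with a five-membered aromatic ring containing one hetero atom, and the read-out stays within the scatter even though the entering group is larger and has no hydrogen-bond acceptor. Both groups carry one hydrogen-bond donor, so this step cannot separate any role of a donor from the rest of the exchange, and no supporting data bear on why the number holds.

Going by these compounds, what a plain phenyl group, with no hydroxyl and no ring nitrogen, would give on this carbon stays open, and it would test whether a donor matters here at all. Equally open, on these data alone, is whether a group carrying a basic amine or a carboxylic acid would be accepted at this position as these two aromatic groups are.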